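A few compounds are considered here, and "the series" means these few. Any claim that something is new, unique, unknown or untested is made for them only; others in the source may bear on it.

Of the compounds shown here, two sharing one core have been measured in a physicochemical assay for lipophilicity, measured as octanol-water partition; on this read-out lower numbers stand for lower lipophilicity and higher numbers for higher lipophilicity. Compound 1 `O=C(COc1cccc2ccccc12)N/N=C/c1ccc(Cl)cc1` gives 4.54 in this assay. Compound 2 `C/C(=N\NC(=O)COc1cccc2ccccc12)c1ccc(O)cc1O` gives 4.31 in this assay. Among the measured compounds shown here, the two numbers lie within the usual scatter of repeated measurements of each other, so compound 1 cannot be set apart from compound 2 on this read-out, and the pair differs in more than one place, so no single-point step between measured compounds is available.

Compound 3 `O=C(COc1cccc2ccccc12)N/N=C/c1ccc(Br)cc1` has not yet been measured. Against compound 1 it differs in one place: bromo in place of chloro on an aromatic carbon. Chloro leaves and bromo enters on an aromatic carbon of a six-membered aromatic ring of carbon only, so that 4-chlorophenyl becomes 4-bromophenyl.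

For the measured compounds named here, no step between measured compounds is known here; the expectation rests on the structural change alone. In this assay the step is expected to be small and upward, a number 0.16 log units higher from compound 1 to compound 3 (within the scatter), quite possibly not beyond the scatter. Compound 3 is accordingly estimated at 4.7, with a range from 4.45 to 4.95.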

Compound 3, partition coefficient: 4.81
Beside the measured number, compound 3's estimate is 0.11 log units below it; measured number inside the range.
By their numbers in this assay, from the lowest: compounds 2, 1 and 3 (each within the scatter of the next, the first and the last beyond it).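

Among the compounds shown here, the exchange of 4-chlorophenyl for 4-bromophenyl gives the first single-place step in this set, and in this assay bromo in place of chloro on an aromatic carbon, para to a large group, reads as a number 0.27 log units higher from compound 1 to compound 3 (within the scatter). For the compounds shown here, at this position, then, one heavy atom can be exchanged for another with no net charge and no hydrogen-bond donors or acceptors on either side, without a step that can be set apart from repeated measurement; the earlier compounds differed in more than one place and could not show this. Nothing available here bears on what lies behind the step.

The compounds shown leave open how this assay would read with an amine, a carboxylic acid or a longer chain, such as a butyl group, at this same position, where the change would alter more than the identity of a single atom. They also leave open whether bromo in place of chloro would give a comparable step on another core, or at another place on this ring.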